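The compounds below may be only part of what the source reports. "The series", "measured", "known", "first", "only" and "open" are said of these compounds alone.

Measured so far:
- compound 1 `CCCCNC(=O)N1CC1C#N`: 17000 nM
- compound 2 `CC(C)(C)NC(=O)N1CC1C#N`: 120000 nM

In a functional assay on RPMI-8226 cells (Homo sapiens) for inhibition (a lower number here means a stronger inhibitor, a higher number a weaker inhibitor), compound 1 gives 17000 nM and compound 2 gives 120000 nM, the highest number of the two, separated from compound 1 by a gap beyond the scatter. Compound 3 `N#CC1CN1C(N)=O` carries the change (hydrogen in place of tert-butyl on an amide-type nitrogen). Going by the values given here, the only measured step bearing on it is a 7.1-fold higher number from compound 1 to compound 2 (0.85 log units; beyond the scatter), which touched the same nitrogen. That step gives no clear sign for removing the group entirely, so the expected step of a 2.4-fold lower number from compound 2 to compound 3 (0.38 log units; beyond the scatter) is uncertain in direction. Compound 3 is estimated at 50000 nM, with a range from 10000 nM to 250000 nM.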

Compound 3, half-maximal inhibitory concentration: 288000 nM
For compound 3 the middle estimate is 5.8-fold (0.76 log units) below the measured one; the measured number lies above the stated range.
By their numbers in this assay, from the lowest: compound 1; then compound 2; then compound 3.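

On the amide-type nitrogen, hydrogen in place of tert-butyl weakens inhibition in this assay (a 2.4-fold higher number from compound 2 to compound 3 (0.38 log units; beyond the scatter)), and hydrogen in place of butyl does so by a larger step (a 17-fold higher number from compound 1 to compound 3 (1.23 log units; beyond the scatter)). Compound 3 is therefore the weakest of the three, and both carbon groups give lower numbers than hydrogen on this nitrogen. No measured evidence accounts for this order. Open, as far as these compounds go, is whether a longer chain, such as hexyl, would fall below compound 1. Also open, from the compounds shown here alone, is how a chain ending in an amine or a carboxylic acid would behave on this nitrogen.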